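The source may report more compounds than this note shows. Statements on the series, on what has been measured and on what is new or still open speak of the compounds shown alone.

Compound 1 `COc1ccc2c(=O)c(/C=C/C(=O)NCc3ccc(C)cc3)coc2c1` gives 10200 nM in a functional assay (QGY7701 cells, Homo sapiens) for inhibition, read by MTT assay, with a stated time of 48 h; a lower number here means a stronger inhibitor, a higher number a weaker inhibitor. Compound 2 `COc1ccc2c(=O)c(/C=C/C(=O)NCc3ccccc3F)coc2c1` gives 34000 nM there, and compound 3 `COc1cccc(NC(=O)/C=C/c2coc3cc(OC)ccc3c2=O)c1` gives 39100 nM, the highest of the three numbers: the step of a 1.2-fold higher number from compound 2 to compound 3 (0.06 log units; within the scatter) stays within the scatter, whereas a 3.8-fold higher number from compound 1 to compound 3 (0.58 log units; beyond the scatter) and a 3.3-fold higher number from compound 1 to compound 2 (0.52 log units; beyond the scatter) lie beyond it. Compound 4 `COc1ccc2c(=O)c(/C=C/C(=O)Nc3ccc(F)cc3)coc2c1` differs from compound 3 in one place: 4-fluorophenyl in place of 3-methoxyphenyl on an amide-type nitrogen. For the measured compounds named here, no measured step swaps one aryl group for another directly on the amide-type nitrogen; the nearest guide is a 1.2-fold higher number from compound 2 to compound 3 (0.06 log units; within the scatter), where a change of the group on that nitrogen left the number within the scatter. A step of about a 1.3-fold lower number from compound 3 to compound 4 (0.12 log units; within the scatter) is therefore expected in this assay, with no direction beyond the scatter. Compound 4 is estimated at 30000 nM, between 10000 nM and 90000 nM.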

Compound 4, half-maximal inhibitory concentration: > 100000 nM
Compound 4: no number, only a limit; the forecaster's own chance of this, stated with the estimate: 15%; middle value at least 3.3-fold (0.52 log units) from the limit.
By their numbers in this assay, from the lowest: compound 1; then compounds 2 and 3 (each within the scatter of the next). At a limit, above all of these: compound 4.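

Compound 4 carries only a limit of the assay, not a number, in this assay: the limit of > 100000 nM in this assay, at which 1 of the 4 values shown sits. The aryl group on this amide-type nitrogen can therefore matter: 4-fluorophenyl in place of 3-methoxyphenyl gives a step beyond the scatter (an at least 2.5-fold higher number from compound 3 to compound 4 (0.40 log units; beyond the scatter)), whereas the earlier change on that nitrogen stayed within it. The steps from the 4-fluorophenyl amide's two benzyl counterparts also lie beyond the scatter (an at least 2.9-fold higher number from compound 2 to compound 4 (0.46 log units; beyond the scatter)) and (an at least 9.8-fold higher number from compound 1 to compound 4 (0.99 log units; beyond the scatter)).

The compounds shown leave open whether 3-fluorophenyl or 4-methoxyphenyl on this nitrogen separates the substituent from its ring position. From the compounds shown here alone, how an aryl group bearing an amine or a carboxylic acid reads there also remains open.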